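The compounds below may be only part of what the source reports. "The series", "measured", "known", "first", "only" and "open" are said of these compounds alone.

Values so far in a functional assay on HL-60 cells (Homo sapiens) for inhibition, read by MTT assay, with a stated time of 72 h, tested at 50 uM; on this read-out higher numbers stand for more inhibition of growth at the one concentration tested and lower numbers for less inhibition of growth

Compound 1 `C=CCc1cc(O)c(O)c(CN2CCC(C)CC2)c1` gives 91.8%
Compound 2 `C=CCc1cc(O)c(O)c(CN2CCC(CCO)CC2)c1` gives 52.1%
Compound 3 `C=CCc1ccc(OCc2cn(-c3ccc(OC)cc3)nn2)c(O)c1` gives 38.9%

Compound 3, at 38.9%, is the lowest of the three numbers. Compound 2 stands higher at 52.1%, and compound 1 is highest at 91.8%.

Compound 4 `C=CCc1ccc(OCc2cn(-c3ccc(Br)cc3)nn2)c(O)c1` keeps the frame of compound 3 and changes one group, 4-methoxyphenyl to 4-bromophenyl: bromo in place of methoxy on an aromatic carbon. In plain words, this is bromo in place of methoxy on an aromatic carbon, para to a large group.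

Among the measured compounds shown here, no measured step tests this swap directly. For the measured compounds named here, the only measured step is a number 39.7 percentage points lower from compound 1 to compound 2 (beyond the scatter), which is large, but it places hydroxymethyl in place of hydrogen on a saturated chain carbon, a different change in a different part of a different pair of compounds. Its size gives no direction here and serves only as a warning that one change can move the number far, so the expected range stays wide.

With no evidence for a direction, the expected a number 4.1 percentage points higher from compound 3 to compound 4 (within the scatter) stays within the usual scatter of this assay and is not a clear change. For compound 4 the estimate is 43%, expected to fall from 25% to 63% in most repeated measurements.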

Compound 4, percent growth inhibition at one concentration: 25.6%
Compound 4: the middle estimate sits 17.4 percentage points above what was measured; the range from low to high includes it.
By their numbers in this assay, from the lowest: compound 4; then compound 3; then compound 2; then compound 1.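

Read in this assay, bromo in place of methoxy on an aromatic carbon, para to a large group, gives a number 13.3 percentage points lower from compound 3 to compound 4 (beyond the scatter), the first measured step at this place on the ring. It shows that the group held here matters on this frame, and that the number can move beyond the usual scatter through a small edit: methoxy, with 2 heavy atoms and 1 hydrogen-bond acceptor, leaves, and bromo, with 1 heavy atom and no hydrogen-bond acceptor, enters. Nothing measured for these compounds says why the number falls with this swap.

Methoxy and bromo are only two groups at this place, too few to give a trend, so it remains open whether plain hydrogen, fluoro, a nitrile or an amine would give a number near compound 3 at 38.9%, near compound 4 at 25.6%, or outside both. From the compounds shown here alone, it also remains open whether the same swap would lower the number on a different frame, such as that of compound 1.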